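This account rests on a few compounds, and the source may have more. Where it says the series, first, only, none or still open, it means among the compounds named here.

Compounds measured in an assay on isolated protein for inhibition of Dihydrofolate reductase (Homo sapiens), read by spectrophotometry, using NADPH, with stated times of 5 s and 6 min, tested at 50 uM; on this read-out lower numbers stand for a weaker effect and higher numbers for a stronger effect at the one concentration tested:
compound 1 `NC1=NC2(CCSCC2)N(OCCCOc2cccc(Cl)c2Cl)C(N)=N1` — 89.8%
compound 3 `NC1=NC2(CCSCC2)N(OCCCOc2ccccc2Cl)C(N)=N1` — 89.6%
compound 2 `NC1=NC2(CCSCC2)N(OCCCOc2ccc(Br)cc2)C(N)=N1` — "not determined" (no result reported)

Among the compounds with values here, compound 3 stands lowest of the two numbers, though its only neighbour is compound 1 and the step of a number 0.2 percentage points lower from compound 1 to compound 3 (within the scatter) lies within the scatter, so the two cannot be told apart. Compound 4 `NC1=NC2(CCSCC2)N(OCCCOc2cccc(Br)c2)C(N)=N1` differs from compound 3 by 3-bromophenyl in place of 2-chlorophenyl on an oxygen on a saturated carbon. Within the data shown here, only one measured step bears on the phenoxy part, a number 0.2 percentage points lower from compound 1 to compound 3 (within the scatter), and it was flat; no measured step moves a halogen between positions on that ring. In this assay compound 4 is therefore expected to show no step beyond the scatter, with a number 1.6 percentage points lower from compound 3 to compound 4 (within the scatter) as the estimated step. Compound 4 is estimated at 88%, in a range from 79% to 95%.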

Compound 4, a percentage reported as inhibition, at one concentration (the size of the read-out at that concentration, not a potency): 86.5%
The estimate for compound 4 lay 1.5 percentage points above the measured number; the range from low to high includes it.
By their numbers in this assay, from the lowest: compounds 4, 3 and 1 (each within the scatter of the next).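

Within the data shown here, replacing 2-chlorophenyl or the 2,3-dichlorophenyl of compound 1 with 3-bromophenyl, on an oxygen on a saturated carbon, produces no step that can be resolved in this assay: a number 3.1 percentage points lower from compound 3 to compound 4 (within the scatter) and a number 3.3 percentage points lower from compound 1 to compound 4 (within the scatter). The phenoxy part thus tolerates a change of halogen and of its ring position together, at least at this single concentration, which gives no potency. Nothing on hand accounts for this flat result. From the compounds shown here alone, whether an amine or a carboxylic acid on this phenyl ring would also leave the read-out unchanged remains open. The same holds for a longer chain on the oxygen.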